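Fluoro for trifluoromethyl on the pendant ring of compound 3

The compounds below may be only part of what the source reports. "The series", "measured", "known", "first", "only" and "open" are said of these compounds alone.

Compound 3 `O=C(O)C1(Sc2ccnc3ccc(-c4ccccc4C(F)(F)F)cc23)CCC1` is tested in an assay on HEK293 cells for inhibition of solute carrier family 22 member 12 (Homo sapiens), read by scintillation counting, with a stated time of 12 min (on this read-out lower numbers stand for stronger inhibition and higher numbers for weaker inhibition), and gives 115 nM. Compound 2 `O=C(O)C1(Sc2ccnc3ccc(C(F)(F)F)cc23)CCC1` gives 61.2 nM, and the two values lie within the usual scatter of each other. Compound 1 `O=C(O)C1(Sc2ccnc3ccc(O)cc23)CCC1` gives > 10000 nM, a limit rather than a number, and so reaches only the limit of > 10000 nM in this assay, at which 1 of the 3 values shown sits, in this assay. Within the data shown here, the one measured step, an at least 160-fold lower number from compound 1 to compound 2 (2.21 log units; beyond the scatter), concerns a different position of the core. Compound 4 `O=C(O)C1(Sc2ccnc3ccc(-c4ccccc4F)cc23)CCC1` differs from compound 3 by fluoro in place of trifluoromethyl on an aromatic carbon. Among the measured compounds shown here, no measured step covers this change, so no shift beyond the scatter is expected. Compound 4 is therefore estimated at 150 nM, between 40 nM and 600 nM, which means an expected step of a 1.3-fold higher number from compound 3 to compound 4 (0.12 log units; within the scatter).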

Compound 4, half-maximal inhibitory concentration: 333 nM
For compound 4 the middle estimate is 2.2-fold (0.35 log units) below the measured one; low and high end bracket the measured number.
By their numbers in this assay, from the lowest: compounds 2 and 3 (each within the scatter of the next); then compound 4. At a limit, above all of these: compound 1.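

In this assay the substituent on the pendant ring proves to matter, since fluoro in place of trifluoromethyl gives a 2.9-fold higher number from compound 3 to compound 4 (0.46 log units; beyond the scatter) and so lies beyond the scatter. Swapping the trifluoromethyl of compound 2 for 2-fluorophenyl gives a 5.4-fold higher number from compound 2 to compound 4 (0.74 log units; beyond the scatter) on the core, a change that compound 3 alone had left within the scatter. Against hydroxy the step of an at least 30-fold lower number from compound 1 to compound 4 (1.47 log units; beyond the scatter) remains large but is read from a limit: the limit of > 10000 nM in this assay, at which 1 of the 4 values shown sits.

On these data alone, what an amine or a nitrile would do at this place on the pendant ring stays open. So does the effect of moving the fluoro elsewhere on that ring.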